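The compounds below may be only part of what the source reports. "The series", "measured", "known", "first", "only" and "open" are said of these compounds alone.

- Compound 1 `C=C(c1ccc(OC)cc1NC(=O)CN(C)C)c1ccc(OC)c2c1OC(C)(C)C=C2` gives 500 nM 
- Compound 2 `C=C(c1cc(OC)c(OC)c(OC)c1)c1ccc(OC)c(O)c1NC(C)=O` gives 270 nM 

These values come from a functional assay on MCF7 cells (Homo sapiens) for antiproliferative activity, read by MTT assay, with a stated time of 48 h (a higher number here means a weaker inhibitor, a lower number a stronger inhibitor), and are the only two available. In that test, compound 2 at 270 nM sits within the usual scatter of compound 1 at 500 nM and so cannot be ranked against it.

Compound 3 `C=C(c1cc(OC)c(OC)c(OC)c1)c1ccc(OC)c(O)c1NC(=O)COC` is compound 2 with one change, (methoxy in place of hydrogen on a saturated chain carbon bound to a carbonyl carbon), which places methoxy in place of hydrogen on a saturated chain carbon bound to a carbonyl carbon. Among the compounds with values here, no measured pair shows this change, so the expectation is cautious, with no shift beyond the scatter. The expected step is a 1.3-fold higher number from compound 2 to compound 3 (0.11 log units; within the scatter) in this estimate. For compound 3 the estimated value is 350 nM, with an expected range from 120 nM to 1000 nM in this test.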

Compound 3, half-maximal inhibitory concentration: 560 nM
The estimate for compound 3 lay 1.6-fold (0.20 log units) below the measured number; the range from low to high includes it.
By their numbers in this assay, from the lowest: compounds 2, 1 and 3 (each within the scatter of the next, the first and the last beyond it).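

With the methoxy in place of hydrogen on a saturated chain carbon bound to a carbonyl carbon, a 2.1-fold higher number from compound 2 to compound 3 (0.32 log units; beyond the scatter) in this assay, so this chain carbon is not indifferent to even a small added group, and here the added methoxy goes with a weaker inhibitor. The step is modest and rests on this single pair, so it sets no general rule. Nothing available accounts for the shift.

As far as these compounds go, whether an amine or a carboxylic acid at this carbon would move the number in the same direction remains open, and so does the effect of a longer chain.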